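The compounds below may be only part of what the source reports. "The series", "measured", "known", "first", "only" and "open" are said of these compounds alone.

Measured so far in a functional assay on T47D cells (Homo sapiens) for cytotoxicity, read by colorimetric assay and MTT assay; a higher number here means a weaker inhibitor, a lower number a stronger inhibitor:
- compound 1 (`COc1ccc(-c2cc3c(OC)cc(OC)cc3n(CC(=O)OCc3ccccc3)c2=O)cc1`) gives 10000 nM
- compound 2 (`COc1ccc(-c2cc3c(OC)cc(OC)cc3n(CCC#N)c2=O)cc1`) gives 10000 nM

On these numbers, compound 2 stands level with compound 1, and it has no other measured neighbour. Compound 3 (`CCN(CC)C(=O)CCn1c(=O)c(-c2ccc(OC)cc2)cc2c(OC)cc(OC)cc21`) keeps the shared core of compound 2 and has not yet been measured. In compound 3, diethylcarbamoyl takes the place of cyano on a saturated chain carbon, two bonds along the chain from an aromatic nitrogen (diethylcarbamoyl in place of cyano on a saturated chain carbon, two bonds along the chain from an aromatic nitrogen).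

Among the measured compounds shown here, only one measured step bears on this change. It is no change at the digits printed from compound 1 to compound 2 (within the scatter), which also alters the group carried on the chain at the aromatic nitrogen. For the measured compounds named here, that single step is thin evidence, and no measured compound carries diethylcarbamoyl. With nothing measured to suggest a direction, no real shift is expected in this assay. The expected change is no change at the digits printed from compound 2 to compound 3 (within the scatter), with no movement beyond the scatter anticipated in either direction. Compound 3 is estimated at 10000 nM, with an expected range from 3000 nM to 25000 nM.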

Compound 3, half-maximal inhibitory concentration: 10000 nM
Beside the measured number, compound 3's estimate shows no gap at the digits printed; measured number inside the range.
By their numbers in this assay, from the lowest: compounds 1, 2 and 3 (each within the scatter of the next).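

In this assay, putting diethylcarbamoyl (7 heavy atoms) in place of cyano (2 heavy atoms) on a saturated chain carbon, two bonds along the chain from an aromatic nitrogen, gives no change at the digits printed from compound 2 to compound 3 (within the scatter) and so leaves the reading where it stood. Set against the benzyloxycarbonyl compound, the longer change gives no change at the digits printed from compound 1 to compound 3 (within the scatter) as well, so compounds 1, 2 and 3 now carry three different groups on this chain without any separation in their numbers. For these three compounds the amide joins the nitrile and the benzyl ester in giving the same reading, but no supporting measurement is available to explain why the readings coincide.

Going by these compounds, whether an amine or a carboxylic acid on this chain, or a longer or shorter chain at the aromatic nitrogen, would separate from these three values remains open. So does whether a change elsewhere on the shared core, such as a hydroxyl group in place of a methoxy group, would move the number in this assay at all.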